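The source may hold more compounds than are shown below. What is called first, only, known or untested is meant among the compounds shown, and "the series" means these compounds.

Working notes on the series. The shared core is that of compound 1 `CN1CCC[C@H](OCc2cc(Cl)cc(Cl)c2)[C@@H]1c1ccccc1`; in an assay on isolated protein for activation of cGMP-dependent protein kinase 1 (Homo sapiens), read by ADP-Glo, with stated times of 120 min and 40 min (on this read-out higher numbers stand for an effect only at larger amounts of compound and lower numbers for an effect already at smaller amounts), compound 1 gives > 200000 nM, which is a limit of the assay and not a number. Compound 3 `O=C(O)c1cncc(CN2CCC[C@H](OCc3cc(Cl)cc(Cl)c3)[C@@H]2c2ccccc2)c1` gives 117000 nM in this assay. Compound 2 `O=C(O)c1ccc(CN2CCC[C@H](O[C@H](CO)c3cc(Cl)cc(Cl)c3)[C@@H]2c2ccccc2)cc1` gives 11000 nM in this assay, the lowest of the two numbers at hand; compound 3 is the nearest, and the gap between them lies beyond the scatter. Going by the values given here, the only measured step, an at least 1.7-fold lower number from compound 1 to compound 3 (0.23 log units; that floor lies within the scatter), places 5-carboxypyridin-3-yl on a saturated chain carbon bound to an amine nitrogen in a ring; its size is a floor set by the limit of > 200000 nM in this assay, at which 1 of the 3 values shown sits.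

Compound 4 `O=C(O)c1ccc2c(CN3CCC[C@H](O[C@H](CO)c4cc(Cl)cc(Cl)c4)[C@@H]3c3ccccc3)c[nH]c2c1` is not yet measured. It differs from compound 2 in one place: 6-carboxy-1H-indol-3-yl in place of 4-carboxyphenyl on a saturated chain carbon bound to an amine nitrogen in a ring. Among the compounds with values here, no measured step exchanges one carboxy-bearing aromatic group for another, so the step from compound 1 to compound 3 bears on it only loosely. Hence the expected step is a 1.4-fold lower number from compound 2 to compound 4 (0.14 log units; within the scatter) in this assay, with no direction beyond the scatter. Compound 4 is estimated at 8000 nM, in the range 2500 nM to 25000 nM.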

Compound 4, half-maximal effective concentration: 22000 nM
Compound 4: the middle estimate sits 2.8-fold (0.44 log units) below what was measured, within the range that was stated.
By their numbers in this assay, from the lowest: compounds 2 and 4 (each within the scatter of the next); then compound 3. At a limit, above all of these: compound 1.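

The exchange of one carboxy-bearing aromatic group for another on a saturated chain carbon bound to an amine nitrogen in a ring gives a 2.0-fold higher number from compound 2 to compound 4 (0.30 log units; within the scatter) in this assay. This place therefore accepts 6-carboxy-1H-indol-3-yl, with its second aromatic ring and 12 heavy atoms against 9, and compound 2 and compound 4 cannot be told apart on this read-out. Nothing measured here accounts for this step.

Still open, on these data alone, is what the acid itself contributes at this place: a primary amide or a tetrazole in place of the carboxylic acid on either aromatic group would test this. As far as these compounds go, compound 2 and compound 3 differ in more than one place, so the separate contribution of the hydroxymethyl branch on the ether chain also stays open.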